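The source may hold more compounds than are shown below. What is called first, only, known or untested is meant among the compounds shown, and "the series" means these compounds.

In a functional assay on PC-3 cells (Homo sapiens) for antiproliferative activity, read by MTT assay, with a stated time of 48 h (a lower number here means a stronger inhibitor, a higher number a weaker inhibitor), compound 1 `COc1ccc(CN(C(=O)CSc2nc3ccccc3s2)c2cc(OC)c(OC)c(OC)c2)cc1O` gives 2110 nM. Within the data shown here, compound 2 `COc1cc(N(Cc2ccccc2)C(=O)CSc2nc3ccccc3s2)cc(OC)c1OC` gives 54100 nM, the higher of the two numbers so far, which makes it the weaker inhibitor of the pair.

The next compound is compound 3 `COc1ccc(CN(C(=O)CSc2nc3ccccc3s2)c2cc(OC)c(OC)c(OC)c2)cc1OC`, with the change 3,4-dimethoxyphenyl in place of phenyl on a saturated chain carbon bound to an amide-type nitrogen.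

Among the measured compounds shown here, one measured step bears on this, at the same place: a 26-fold higher number from compound 1 to compound 2 (1.41 log units; beyond the scatter), large and beyond the scatter, with phenyl in place of 3-hydroxy-4-methoxyphenyl. That single step shows the number rising when the substituted phenyl gives way to phenyl. For the measured compounds named here, no measured compound yet shows how 3,4-dimethoxyphenyl itself behaves here, so the size of the new step is uncertain.

A step toward a lower number, beyond the scatter but probably smaller than the measured one, is therefore expected. The expected change is an 11-fold lower number from compound 2 to compound 3 (1.03 log units; beyond the scatter). For compound 3 the estimated value is 5000 nM, with an expected range of 1000 nM to 20000 nM.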

Compound 3, half-maximal inhibitory concentration: > 80000 nM
Compound 3 was reported as a limit (the forecaster's own chance of this, stated with the estimate: 5%); middle value at least 16-fold (1.20 log units) away from the limit.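

In this assay compound 3 is reported only as a limit of the assay, not as a number: the limit of > 80000 nM in this assay, at which 1 of the 3 values shown sits.

Even so, the limit is enough for one clear reading: an at least 37-fold higher number from compound 1 to compound 3 (1.57 log units; beyond the scatter), with methyl in place of hydrogen on an oxygen on an aromatic ring as the only change, so in this pair the lower number of compound 1 goes with that single hydrogen and not with oxygen substituents on the benzyl group as such. The other reading is weaker: an at least 1.4-fold higher number from compound 2 to compound 3 (0.16 log units; that floor lies within the scatter), a floor that does not separate the two compounds, but benzyl to 3,4-dimethoxybenzyl brings no drop in the number like the one seen with the 3-hydroxy-4-methoxyphenyl group of compound 1.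

On these data alone, how far compound 3 really lies from compound 2 stays open, as does whether the methoxy group of the 3-hydroxy-4-methoxyphenyl group contributes anything to the number of compound 1. An amine in place of the hydroxy group at this position would show whether the hydroxy group itself is needed or whether another group carrying hydrogen can stand in for it.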